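This account rests on a few compounds, and the source may have more. Where it says the series, first, only, none or still open, it means among the compounds named here.

Measured compounds:
compound 1 `C#CCSc1nc(Nc2ccccc2Cl)c(C#N)c(-c2ccccc2)n1` — in a functional assay on ECa-109 cells (Homo sapiens) for inhibition, read by MTT assay, with a stated time of 72 h (on this read-out higher numbers stand for weaker inhibition and lower numbers for stronger inhibition), compound 1 gives > 128000 nM, which is a limit of the assay rather than a number.
compound 2 `COc1ccc(Nc2nc(SCc3cn(Cc4ccccc4Cl)nn3)nc(-c3ccccc3)c2C#N)cc1` — in this assay compound 2 gives 7960 nM.

Among the measured compounds shown here, of the two results, that of compound 2 is the only one that is a number; the other result is a limit, as the line the limit of > 128000 nM in this assay, at which 1 of the 2 values shown sits, states. Compound 2 therefore stands alone as the single measured anchor, with nothing to rank it against.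

Compound 3 `N#Cc1c(Nc2cccc(C(F)(F)F)c2)nc(SCc2cn(Cc3ccccc3Cl)nn2)nc1-c1ccccc1` is not yet measured. It differs from compound 2 in one place: 3-(trifluoromethyl)phenyl in place of 4-methoxyphenyl on a nitrogen on an aromatic ring. For the measured compounds named here, no pair of measured compounds shows what this kind of exchange does, so there is no measured step to lean on. Since the shared core, the nitrile, the phenyl and the sulfur-linked triazole arm with its chlorobenzyl group are all kept, the expectation for the step from compound 2 to compound 3 is a change of modest size, most likely not beyond the usual scatter, in either direction a 1.0-fold higher number from compound 2 to compound 3 (0.00 log units; within the scatter). In this assay compound 3 is expected to give about 8000 nM, with a plausible span from 2500 nM to 30000 nM.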

Compound 3, half-maximal inhibitory concentration: 32000 nM
Beside the measured number, compound 3's estimate is 4.0-fold (0.60 log units) below it, and the stated range ends below it.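

Among the compounds shown here, this is the first measured exchange of the aromatic group on a nitrogen on an aromatic ring, and in this assay replacing 4-methoxyphenyl with 3-(trifluoromethyl)phenyl gives a 4.0-fold higher number from compound 2 to compound 3 (0.60 log units; beyond the scatter). The step is modest but beyond the scatter, so this position is not indifferent to what it carries: with the shared core, the nitrile, the phenyl and the sulfur-linked triazole arm with its chlorobenzyl group all kept, this one exchange is enough to weaken inhibition in the cells. No measured result here bears on why the number rises.

The exchange changes both the substituent and its place on the ring, and the compounds shown cannot separate these two changes, so it stays unclear which of them matters, or whether both do. Also open, on these data alone, is how this single step would extend to other groups on this nitrogen, such as an unsubstituted phenyl, a carboxylic acid on the ring, or a simple ethyl chain in place of the ring.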